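Replacing diethylcarbamoyl with cyano after a flat step

A few compounds are considered here, and "the series" means these few. Any claim that something is new, unique, unknown or untested is made for them only; others in the source may bear on it.

Compound 1 (`CCOC(=O)Cn1c(=O)c(-c2ccc(OC)cc2)cc2c(OC)cc(OC)cc21`) gives (10000 nM)
Compound 2 (`CCN(CC)C(=O)Cn1c(=O)c(-c2ccc(OC)cc2)cc2c(OC)cc(OC)cc21`) gives (10000 nM)

Both values come from (a functional assay on U-87MG ATCC cells for cytotoxicity against U-87 MG (Homo sapiens), read by colorimetric assay and MTT assay; on this read-out higher numbers stand for weaker inhibition and lower numbers for stronger inhibition). Compound 2 stands level with compound 1, its only measured neighbour, at the digits shown. Among the compounds with values here, the single measured step (no change at the digits printed from compound 1 to compound 2 (within the scatter)) put diethylamino in place of ethoxy on a carbonyl carbon and stayed within the scatter. Compound 3 (`COc1ccc(-c2cc3c(OC)cc(OC)cc3n(CC#N)c2=O)cc1`) carries cyano in place of diethylcarbamoyl on a saturated chain carbon bound to an aromatic nitrogen. Within the data shown here, this change removes more of the side chain than the measured step did, and no measured compound carries cyano, so that step is only partial guidance. Among the measured compounds shown here, still, the one available step is flat, so no step beyond the scatter is expected in (this assay), in either direction. The expected change is (no change at the digits printed from compound 2 to compound 3 (within the scatter)). Compound 3 is estimated at (10000 nM), with an expected range from (4000 nM) to (20000 nM).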

Compound 3, half-maximal inhibitory concentration: 10000 nM
For compound 3 middle estimate and measured number coincide at the digits printed, and the stated range covers the measured number.
By their numbers in this assay, from the lowest: compounds 1, 2 and 3 (each within the scatter of the next).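

Across the cyano swap, this assay again shows a flat result: no change at the digits printed from compound 2 to compound 3 (within the scatter) with cyano in place of diethylcarbamoyl, and no change at the digits printed from compound 1 to compound 3 (within the scatter) with cyano in place of ethoxycarbonyl. The earlier pair varied only what was attached to the carbonyl, whereas compound 3 has no carbonyl on this side chain and carries a group of 2 heavy atoms in place of one of 7. On a saturated chain carbon bound to an aromatic nitrogen, neither removing that carbonyl nor this reduction in size shows up in the reading, and no measurement here accounts for that.

The compounds shown leave open whether a primary amine, a carboxylic acid or a longer chain at this place would shift the reading. They also leave open whether changes elsewhere on the shared core would do so.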